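A tert-Butyl Added to the Benzoate Ester of Compound 3

A few compounds are considered here, and "the series" means these few. Any claim that something is new, unique, unknown or untested is made for them only; others in the source may bear on it.

Compound 3 `O=C(OCCCc1cn(-c2ccnc3cc(Cl)ccc23)nn1)c1ccccc1` gives 1200000 nM in an ADME assay on HepG2 cells (Homo sapiens) for cytotoxicity, read by MTT assay, with a stated time of 24 h (a higher number here means that more compound is tolerated, a lower number that less compound is tolerated), the higher of the two numbers available; its nearest neighbour, compound 2 `Cc1ccc(-c2cn(-c3ccnc4cc(Cl)ccc34)nn2)cc1`, gives 352000 nM, a lower number beyond the scatter. Compound 1 `CN(C)c1ccc(-c2cn(-c3ccnc4cc(Cl)ccc34)nn2)cc1` gives only a limit of the assay, > 2860000 nM, in this assay. Going by the values given here, the single measured step, an at least 8.1-fold lower number from compound 1 to compound 2 (0.90 log units; beyond the scatter), also sits on an aromatic carbon, but it swaps one group for another rather than adding one, so it bears only loosely on the present change. Compound 4 `CC(C)(C)c1ccc(C(=O)OCCCc2cn(-c3ccnc4cc(Cl)ccc34)nn2)cc1` differs from compound 3 by tert-butyl in place of hydrogen on an aromatic carbon. Without a close precedent, a step of a 2.0-fold lower number from compound 3 to compound 4 (0.30 log units; within the scatter) is expected, toward a lower number. Compound 4 is therefore estimated at 600000 nM, within 150000 nM to 2400000 nM.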

Compound 4, half-maximal cytotoxic concentration: > 2230000 nM
Compound 4 ended at the assay's limit; the forecaster's own chance of this, stated with the estimate: 20%; middle value at least 3.7-fold (0.57 log units) away from the limit.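

In this assay compound 4 gives a limit of the assay, not a number: the limit of > 2230000 nM in this assay, at which 1 of the 4 values shown sits. The change therefore reads as an at least 1.8-fold higher number from compound 3 to compound 4 (0.26 log units; that floor lies within the scatter), a floor only. Unlike the earlier swap of one group for another, it shows that tert-butyl added at this aromatic carbon of the benzoate does not give the lower number expected, though how far the true value lies beyond the floor remains unknown. On these data alone, what an amine or a carboxylic acid at the same carbon would do stays open.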